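Dropping the methoxy from compound 1: a lipophilicity estimate

A few compounds are considered here, and "the series" means these few. Any claim that something is new, unique, unknown or untested is made for them only; others in the source may bear on it.

Two compounds in this set carry numbers in a physicochemical assay for lipophilicity, at pH 7.4; a lower number here means a more polar compound, a higher number a more lipophilic compound. Compound 1 `CCCCCCCc1c(C)nc2cc(OC)ccc2c1O` gives 3.69 in this assay, the higher of the two measured values. Compound 2 `COc1ccc2c(=O)cc(C)[nH]c2c1` gives 1.2 in this assay, a reading that lies well below compound 1 by a margin far beyond the scatter of repeated measurements. Nothing links compound 2 to compound 1 by a single change of structure, so the two values are simply noted side by side.

The step under consideration leads from compound 1 to compound 3 `CCCCCCCc1c(C)nc2ccccc2c1O`, which has not yet been measured in this assay. The change is hydrogen in place of methoxy on an aromatic carbon. Going by the values given here, no measured pair in the set shows this kind of change, so there is no precedent to draw on here. For this assay, the step from compound 1 to compound 3 is expected to be small, estimated at a number 0.04 log units lower from compound 1 to compound 3 (within the scatter), with no clear direction beyond the usual scatter. Compound 3 is therefore estimated to give 3.65 in this assay, within an expected range from 3.3 to 4.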

Compound 3, distribution coefficient: 3.39
Beside the measured number, compound 3's estimate is 0.26 log units above it; the range from low to high includes it.
By their numbers in this assay, from the lowest: compound 2; then compounds 3 and 1 (each within the scatter of the next).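

The set now holds its first step with a single change: in this assay, hydrogen in place of methoxy on an aromatic carbon, meta to a fused ring and para to a fused ring, reads as a number 0.30 log units lower from compound 1 to compound 3 (within the scatter). At this position, then, the methoxy can give way to hydrogen without the reading leaving the scatter, so this measure does not separate compound 3 from compound 1, whereas the earlier pair of compounds differed in more than one place and could show nothing about this change alone. Nothing at hand gives a reason for this outcome, and no separate measurement bears on it.

Whether the same aromatic carbon would stay as quiet in this assay with a fluorine, an amine or a carboxylic acid in place of the hydrogen remains open, as the compounds shown carry only methoxy or hydrogen there. Also open, going by these compounds, is whether the step would keep its size on a core with a shorter chain in place of the long chain of compound 1.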